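The source may report more compounds than this note shows. Statements on the series, on what has been measured and on what is new or still open speak of the compounds shown alone.

Measured compounds, with their numbers in an assay on CHO cells for displacement of a labelled ligand from 5-hydroxytryptamine receptor 1D (Homo sapiens); on this read-out higher numbers stand for weaker inhibition and lower numbers for stronger inhibition:
compound 1 `C[C@@H](NC1CCN(CCCc2c[nH]c3ccc(-n4cnnc4)cc23)CC1)c1ccccc1`: 0.4 nM
compound 2 `CC(C)=CCN(C)C1CCN(CCCc2c[nH]c3ccc(-n4cnnc4)cc23)CC1`: 0.5 nM
compound 3 `CN(Cc1ccsc1)C1CCN(CCCc2c[nH]c3ccc(-n4cnnc4)cc23)CC1`: 1.5 nM

Compound 1 gives the lowest number of the three. Its nearest neighbour is compound 2, a 1.3-fold higher number from compound 1 to compound 2 (0.10 log units; within the scatter), so the two cannot be told apart. Compound 3 stands further off, a 3.8-fold higher number from compound 1 to compound 3 (0.57 log units; beyond the scatter), and a 3.0-fold higher number from compound 2 to compound 3 (0.48 log units; beyond the scatter) points the same way. All three measured steps alter the substituent on the saturated ring carbon; the aromatic part of the shared core is constant throughout.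

Compound 4 `CNS(=O)(=O)Cc1ccc2[nH]cc(CCCN3CCC(N[C@H](C)c4ccccc4)CC3)c2c1` departs from compound 1 elsewhere: (methylsulfamoyl)methyl in place of 4H-1,2,4-triazol-4-yl on an aromatic carbon. Among the measured compounds shown here, none of the measured steps touches this position, so none bears directly on the change, and the measured series gives no gauge of its size or direction. The expectation therefore rests on compound 1 alone, with broad uncertainty in both directions. On that basis compound 4 is expected to sit near compound 1, a 2.5-fold higher number from compound 1 to compound 4 (0.40 log units; beyond the scatter), and the estimate for compound 4 in this assay is 1 nM, with a range of 0.2 nM to 6 nM.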

Compound 4, half-maximal inhibitory concentration: 43 nM
Compound 4: the middle estimate sits 43-fold (1.63 log units) below what was measured; the whole stated range lies below it.
By their numbers in this assay, from the lowest: compounds 1 and 2 (each within the scatter of the next); then compound 3; then compound 4.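

In this assay, (methylsulfamoyl)methyl in place of 4H-1,2,4-triazol-4-yl on this aromatic carbon gives a 110-fold higher number from compound 1 to compound 4 (2.03 log units; beyond the scatter) with the rest of compound 1 unchanged, so the read-out depends strongly on this position. That step far exceeds the largest step seen on the saturated ring carbon, which is a 3.8-fold higher number from compound 1 to compound 3 (0.57 log units; beyond the scatter) and shows that the aromatic position carries more of the variation in these compounds. Nothing available accounts for the size of the step at the aromatic carbon.

The compounds shown leave open whether the loss follows from removing the ring, from the sulfonamide or from the methylene link, which a 1,2,3-triazole, a directly attached methylsulfamoyl group or a dimethylsulfamoylmethyl group would help separate. Also open, going by these compounds, is whether the same exchange costs as much with the amine substituent of compound 2 in place.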